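This account rests on a few compounds, and the source may have more. Where it says the series, first, only, none or still open, it means among the compounds named here.

Measured so far:
Compound 1 `COc1ccc2nc(C)cc(OCC(=O)Nc3cc(C)ccc3OC)c2c1`: in a toxicity assay on HepG2 cells (Homo sapiens) for inhibition, read by CellTiter-Glo, with a stated time of 48 h (on this read-out higher numbers stand for weaker inhibition and lower numbers for stronger inhibition), compound 1 gives > 100000 nM, which is a limit of the assay rather than a number.
Compound 2 `COc1ccc2nc(C)cc(OCC(=O)Nc3ccc(F)cc3)c2c1`: in this assay compound 2 gives 63100 nM.

Among the measured compounds shown here, compound 2 thus holds the only real number in this assay; the other result is a limit. For the measured compounds named here, the single measured step, an at least 1.5-fold lower number from compound 1 to compound 2 (0.19 log units; that floor lies within the scatter), is read against (the limit of > 100000 nM in this assay, at which 1 of the 2 values shown sits), so its true size is not known beyond that floor. Compound 3 `COc1ccc2nc(C)cc(OCC(=O)Nc3nccs3)c2c1` differs from compound 2 in one place: 1,3-thiazol-2-yl in place of 4-fluorophenyl on an amide-type nitrogen. Going by the values given here, no measured step swaps a six-membered aromatic ring of carbon only for a five-membered aromatic ring with two hetero atoms, so the only guide is that the one measured change on this amide-type nitrogen, an at least 1.5-fold lower number from compound 1 to compound 2 (0.19 log units; that floor lies within the scatter), reached a size the scatter can cover. The step from compound 2 to compound 3 is therefore expected to be small, a 1.1-fold higher number from compound 2 to compound 3 (0.05 log units; within the scatter), with no settled direction. Compound 3 is estimated at 70000 nM, between 20000 nM and 150000 nM, and a limit instead of a number is a real possibility.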

Compound 3, half-maximal inhibitory concentration: > 100000 nM
Compound 3 ended at the assay's limit (the forecaster's own chance of this, stated with the estimate: 40%); at least 1.4-fold (0.15 log units) between middle value and limit.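

Placing 1,3-thiazol-2-yl instead of 4-fluorophenyl on the amide-type nitrogen tests a five-membered aromatic ring with 2 hetero atoms at this position, and in this assay the change gives an at least 1.5-fold higher number from compound 2 to compound 3 (0.19 log units; that floor lies within the scatter). Among the compounds shown here, this swap therefore brings no sign of stronger inhibition in this toxicity read-out, and compound 2, with its 4-fluorophenyl group, remains the only one of the three compounds with a real number rather than a limit. The true size of that step is unknown beyond its floor, and the step between the other two compounds cannot be read, because compound 1 and compound 3 both end at a limit: the limit of > 100000 nM in this assay, at which 2 of the 3 values shown sit.

The compounds shown leave open whether a cyclohexyl ring, a pyridine ring or a longer chain such as benzyl on this same nitrogen would give a real number in this assay, and whether any such group would move it clearly beyond the scatter from compound 2. Going by these compounds, all three compounds also keep the same core and the same oxygen-linked acetamide chain, so the effect of changing either remains unknown.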